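A few compounds are considered here, and "the series" means these few. Any claim that something is new, unique, unknown or untested is made for them only; others in the source may bear on it.

Of the compounds shown here, three built on one shared core have been tested in an assay on isolated protein for inhibition of DNA topoisomerase 1 (Homo sapiens), with a stated time of 30 min, tested at 100 uM; a higher number here means a stronger effect of the compound at the concentration tested, a lower number a weaker effect. Compound 1 `Oc1cccc(-c2cc(-c3ccc(Cl)cc3)nc(-c3cccs3)c2)c1` gives 15.1%, compound 2 `Oc1cccc(-c2cc(-c3cccc(Cl)c3)nc(-c3ccco3)c2)c1` gives 5.5%, and compound 3 `Oc1cccc(-c2cc(-c3ccccc3)nc(-c3ccc(Cl)cc3)c2)c1` gives 7.1%. On these three numbers compound 3 stands second highest; its nearest neighbour is compound 2 and its furthest is compound 1, and both gaps lie within the usual scatter of repeated measurements, so no ordering among the three can be claimed.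

Compound 4 `Oc1cccc(-c2cc(-c3ccc(Cl)cc3)nc(-c3ccco3)c2)c1` has not yet been measured. It differs from compound 3 in a single place: furan-2-yl in place of phenyl on an aromatic carbon. For the measured compounds named here, only one measured step bears on such a swap of one aromatic ring for another on an aromatic carbon of the core: a number 8 percentage points lower from compound 1 to compound 3 (within the scatter), a step that stayed within the scatter. Compound 2 also carries a furan-2-yl ring, but it differs from compound 4 in more than one place, so all that can be said is that compound 2 shows 5.5%, a number close to that of compound 3.

Going by the values given here, since the one comparable step is within the scatter, compound 4 is expected to give about 8%, in a range from 0% to 20%. The expected step, a number 0.9 percentage points higher from compound 3 to compound 4 (within the scatter), is estimated to stay within the scatter.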

Compound 4, a percentage reported as inhibition, at one concentration (the size of the read-out at that concentration, not a potency): 27.1%
Compound 4: the middle estimate sits 19.1 percentage points below what was measured, outside the stated range (above it).
By their numbers in this assay, from the lowest: compounds 2, 3 and 1 (each within the scatter of the next); then compound 4.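

For the compounds shown here, compound 4 shows that the aromatic ring next to the ring nitrogen can matter in this assay: furan-2-yl in place of phenyl gives a number 20 percentage points higher from compound 3 to compound 4 (beyond the scatter) and furan-2-yl in place of thiophen-2-yl gives a number 12 percentage points higher from compound 1 to compound 4 (beyond the scatter) while the only earlier step at this place, a number 8 percentage points lower from compound 1 to compound 3 (within the scatter), gave no readable difference. Furan-2-yl alone does not account for the higher number, since 4-chlorophenyl in place of 3-chlorophenyl, with furan-2-yl present in both compounds, gives a number 21.6 percentage points higher from compound 2 to compound 4 (beyond the scatter) and so shows that the chlorine's place on the other ring counts as well. No measurement shown here explains either change.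

On these data alone, it remains open whether furan-2-yl would give a similar step with a partner other than 4-chlorophenyl, and whether a non-aromatic group at this place, such as an amine or a short alkyl chain, would keep, lower or raise the number. All of these numbers also come from a single tested concentration, so they show only how strong the effect of compound 4 is at that concentration and leave its effect at other concentrations open.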